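Shorter allyloxy chain on the shared core: compound 4

The source may hold more compounds than are shown below. What is called first, only, known or untested is meant among the compounds shown, and "the series" means these compounds.

Measured so far:
compound 1 `O=c1c(-c2ccc(O)cc2)coc2cc(OCCCBr)ccc12`: 67.7%
compound 2 `O=C(O)CCCCCCOc1ccc2c(=O)c(-c3ccc(O)cc3)coc2c1`: 71.2%
compound 3 `O=c1c(-c2ccc(O)cc2)coc2cc(OCCC3OCCCO3)ccc12`: 57.6%

In a functional assay on mitochondria (Cricetulus griseus) for inhibition of Monoamine oxidase (Homo sapiens), tested at 0.9 uM (on this read-out higher numbers stand for a stronger effect at the one concentration tested and lower numbers for a weaker effect), compound 1 stands second highest of the three, with compound 2 nearest to it and compound 3 furthest from it. Compound 4 `C=CCOc1ccc2c(=O)c(-c3ccc(O)cc3)coc2c1` differs from compound 1 as follows: vinyl in place of 2-bromoethyl on a saturated chain carbon bound to an oxygen on an aromatic ring. Going by the values given here, no measured step shortens the chain in this way; the steps known replace the bromo end of the chain and give a number 3.5 percentage points higher from compound 1 to compound 2 (within the scatter) and a number 10.1 percentage points lower from compound 1 to compound 3 (beyond the scatter). Both keep the result within a modest span of compound 1, so a step of at most modest size, if any, is expected, with the direction uncertain: a number 5.7 percentage points lower from compound 1 to compound 4 (within the scatter). Compound 4 is therefore estimated at 62%, in the range 48% to 76%.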

Compound 4, a percentage reported as inhibition, at one concentration (the size of the read-out at that concentration, not a potency): 68.8%
Estimate against measurement, compound 4: 6.8 percentage points below, and the stated range covers the measured number.
By their numbers in this assay, from the lowest: compound 3; then compounds 1, 4 and 2 (each within the scatter of the next).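

Swapping 2-bromoethyl for vinyl leaves the read-out in this assay unchanged within the scatter (a number 1.1 percentage points higher from compound 1 to compound 4 (within the scatter)), and replacing 5-carboxypentyl with vinyl does the same (a number 2.4 percentage points lower from compound 2 to compound 4 (within the scatter)). Thus, neither the bromine nor the carboxylic acid is needed to hold this level on the shared core. Vinyl also stands clear of the ring-bearing group of compound 3 (a number 11.2 percentage points higher from compound 3 to compound 4 (beyond the scatter)), which alone sits apart, and nothing here gives a reason for this. From the compounds shown here alone, whether an amine at the chain end or a longer unbranched alkyl chain would hold this level remains open. So does whether the effects seen at this one concentration would stay level at other concentrations.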